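This account rests on a few compounds, and the source may have more. Where it says the series, first, only, none or still open, it means among the compounds named here.

Measured so far:
compound 1 `COC1=C(C)C(=O)C2=C(O[C@]3(CC[C@]45[C@H]([C@H](C(C)C)CC[C@H]4C)[C@@H]35)C[C@H]2C(C)C)C1(C)C` — 30500 nM
compound 2 `COC1=C(C)C(=O)C2=C(O[C@@]3(C=C4[C@H](C(C)C)CC[C@@H](C)[C@H]4CC3)C[C@@H]2C(C)C)C1(C)C` — 18800 nM

In a functional assay on RAW264.7 cells (Mus musculus) for inhibition, read by Griess assay, with stated times of 2 h and 20 h (on this read-out higher numbers stand for weaker inhibition and lower numbers for stronger inhibition), compound 1 gives 30500 nM, the larger of the two numbers, while compound 2 gives 18800 nM; the gap between them lies within the scatter, so nothing separates the two. Compound 3 `COC1=C(C)C(=O)C2=C(O[C@@]3(CC[C@]45[C@H]([C@H](C(C)C)CC[C@H]4C)[C@@H]35)C[C@@H]2C(C)C)C1(C)C` remains to be measured. It differs from compound 1 as follows: the two compounds have the same atoms and bonds and differ only in configuration as drawn: 2 of 7 stereo elements differ; a stereocentre at a saturated ring carbon is drawn R in compound 1 and S in compound 3; a stereocentre at a saturated ring carbon is drawn S in compound 1 and R in compound 3. Going by the values given here, no measured pair differing only in configuration is available, so the data give no size for such a step; a change within the scatter, in no fixed direction, is expected. Compound 3 is estimated at 25000 nM (range 9000 nM to 70000 nM), the step of a 1.2-fold lower number from compound 1 to compound 3 (0.09 log units; within the scatter) being expected to stay within the scatter.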

Compound 3, half-maximal inhibitory concentration: 15200 nM
Estimate against measurement, compound 3: 1.6-fold (0.22 log units) above; low and high end bracket the measured number.
By their numbers in this assay, from the lowest: compounds 3, 2 and 1 (each within the scatter of the next).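

In this assay, compounds 1 and 3 form the first measured pair differing only in configuration, and a 2.0-fold lower number from compound 1 to compound 3 (0.30 log units; within the scatter) gives the series its first size for such a step. This step stays within the scatter, so the two saturated ring stereocentres drawn differently do not separate the pair in this read-out. The comparison rests on a single structural difference: the fact that compounds 1 and 3 differ only in the configuration as drawn.

Open, going by these compounds, is whether either stereocentre alone has any effect, and whether an amine or a carboxylic acid on the shared core would give a step beyond the scatter.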